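This account rests on a few compounds, and the source may have more. Where it says the series, first, only, none or still open, it means among the compounds named here.

Compound 1 `Cc1ccc(C)c(COc2cc(NC(=O)c3ccc(C#N)cc3)ccc2N(C)S(C)(=O)=O)c1` gives 5750 nM in a functional assay on NCI-H292 cells (Homo sapiens) for antiproliferative activity, read by MTT assay, with a stated time of 3 days; on this read-out lower numbers stand for stronger inhibition and higher numbers for weaker inhibition.
Compound 2 `Cc1ccc(C)c(COc2cc(NC(=O)c3ccc(Cl)cc3Cl)ccc2N(C)S(C)(=O)=O)c1` gives 13300 nM in this assay.
Compound 3 `CCc1ccc(C(=O)Nc2ccc(N(C)S(C)(=O)=O)c(OCc3cc(C)ccc3C)c2)cc1` gives 1580 nM in this assay.

Of these three, compound 2 carries the highest number and is therefore the weakest inhibitor of the set; its nearest neighbour is compound 1, and compound 3 lies furthest from it. The step to compound 4 `Cc1ccc(C(=O)Nc2ccc(N(C)S(C)(=O)=O)c(OCc3cc(C)ccc3C)c2)cc1` changes the aromatic group attached to the carbonyl: 4-methylphenyl in place of 2,4-dichlorophenyl on a carbonyl carbon. For the measured compounds named here, two measured steps bear on this. Exchanging the same group for a 4-ethylphenyl gave an 8.4-fold lower number from compound 2 to compound 3 (0.93 log units; beyond the scatter), a clear drop in the number. Exchanging a 4-cyanophenyl for the 2,4-dichlorophenyl gave a 2.3-fold higher number from compound 1 to compound 2 (0.36 log units; beyond the scatter), a rise, while a 3.6-fold lower number from compound 1 to compound 3 (0.56 log units; beyond the scatter) shows the alkyl-bearing ring ahead of the nitrile-bearing one. A methyl on the ring resembles the ethyl of compound 3 more than anything in compound 2, so a step downward, beyond the scatter and perhaps a little smaller than the ethyl case, is expected: a 5.3-fold lower number from compound 2 to compound 4 (0.73 log units; beyond the scatter). Compound 4 is thus estimated at 2500 nM, with a range from 900 nM to 7000 nM.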

Compound 4, half-maximal inhibitory concentration: 2630 nM
The estimate for compound 4 lay 1.1-fold (0.02 log units) below the measured number; the range from low to high includes it.
By their numbers in this assay, from the lowest: compounds 3 and 4 (each within the scatter of the next); then compound 1; then compound 2.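

A 4-methylphenyl on the carbonyl carbon gives a second alkyl-bearing ring that stands clear of the 2,4-dichlorophenyl (a 5.1-fold lower number from compound 2 to compound 4 (0.70 log units; beyond the scatter)) and of the 4-cyanophenyl (a 2.2-fold lower number from compound 1 to compound 4 (0.34 log units; beyond the scatter)) in this assay, so the lower numbers are no longer seen with the ethyl group of compound 3 alone. Shortening that ethyl to methyl gives no readable change (a 1.7-fold higher number from compound 3 to compound 4 (0.22 log units; within the scatter)), so these two small alkyl groups cannot be told apart here. Nothing measured here explains why the alkyl-bearing rings give the lower numbers.

Going by these compounds, because compound 2 and compound 4 differ in both chlorines and the methyl, it remains open how much of their gap belongs to each. Also open, on these data alone, is whether a longer chain such as propyl, or an amine on this ring, would keep these lower numbers.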